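Chloro for fluoro on the sulfonyl ring of a piperidinone scaffold

The compounds below may be only part of what the source reports. "The series", "measured", "known", "first", "only" and "open" are said of these compounds alone.

Measured compounds:
compound 1, `O=C1/C(=C/c2ccncc2)CN(S(=O)(=O)c2ccc(F)cc2)C/C1=C\c1ccccc1F`: > 20000 nM
compound 2, `O=C1/C(=C/c2ccncc2)CN(S(=O)(=O)c2ccc(Cl)cc2)C/C1=C\c1ccccc1F`: 9600 nM
compound 3, `O=C1/C(=C/c2cccnc2)CN(S(=O)(=O)c2ccc(F)cc2)C/C1=C\c1ccccc1C(F)(F)F`: 6390 nM

Of the compounds shown here, three have been tested in a functional assay on SMMC-7721 cells (Homo sapiens) for cytotoxicity, read by MTT assay, with a stated time of 24 h; on this read-out higher numbers stand for weaker inhibition and lower numbers for stronger inhibition. In this assay compound 1 gives > 20000 nM, which is a limit of the assay and not a number. Compound 2 differs from compound 1 in one place, (chloro in place of fluoro on an aromatic carbon), and this gives an at least 2.0-fold lower number from compound 1 to compound 2 (0.31 log units; beyond the scatter); the step can only be bounded, because of the limit of > 20000 nM in this assay, at which 1 of the 3 values shown sits. Compound 3 gives 6390 nM, and against compound 2 the two numbers lie within the usual scatter of each other, so no order between them can be read. The difference between the core of compound 3 and the core of compound 1 is not broken down here.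

Compound 4, `O=C1/C(=C/c2cccnc2)CN(S(=O)(=O)c2ccc(Cl)cc2)C/C1=C\c1ccccc1C(F)(F)F`, has not yet been measured. It differs from compound 3 by chloro in place of fluoro on an aromatic carbon, which is the same change as that from compound 1 to compound 2, at the same place. Resting on the bounded step seen from compound 1 to compound 2, compound 4 is expected to give a lower number than compound 3 in this assay, with an estimated step of a 2.0-fold lower number from compound 3 to compound 4 (0.30 log units; within the scatter). The estimate for compound 4 is 3200 nM, expected to fall between 1500 nM and 7000 nM.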

Compound 4, half-maximal inhibitory concentration: 4880 nM
Estimate against measurement, compound 4: 1.5-fold (0.18 log units) below; the range from low to high includes it.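

On the core of compound 3, the change from 4-fluorophenyl to 4-chlorophenyl on the sulfonyl group gives, in this assay, a 1.3-fold lower number from compound 3 to compound 4 (0.12 log units; within the scatter), so on this core the two numbers cannot be told apart from repeated measurement. Set beside the step on the first core, the result reads: the same change on two cores in this assay, an at least 2.0-fold lower number (0.31 log units; beyond the scatter) from compound 1 to compound 2 and a 1.3-fold lower number (0.12 log units; within the scatter) from compound 3 to compound 4; the limit leaves it open whether they differ. The direction of the printed step on the second core matches that on the first, but this step is too small to count as a real change, and the pair does not show whether the swap carries over from one core to the other with the same size, since the value of compound 1 is a limit and not a number: the limit of > 20000 nM in this assay, at which 1 of the 4 values shown sits.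

The compounds shown carry only fluoro and chloro at this place on the sulfonyl ring, which leaves open how a bromo group, a methoxy group or an amine there would read in this assay. Also open, as far as these compounds go, is whether the swap would read the same on a further core, for instance one with a nitrile where compound 3 and compound 4 have their trifluoromethyl group.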